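Adding Fluorine to Compound 2: What to Expect

The source may report more compounds than this note shows. Statements on the series, on what has been measured and on what is new or still open speak of the compounds shown alone.

Of the compounds shown here, two that share a core have been measured in a functional assay on L1210 cells (Mus musculus) for inhibition; on this read-out higher numbers stand for weaker inhibition and lower numbers for stronger inhibition. Compound 1 `O=C1/C(=C/c2ccc(Br)cc2)Cc2ccccc21` gives 64800 nM in this assay. Compound 2 `O=C1/C(=C/c2ccccc2)CCc2ccccc21` gives 121000 nM in this assay; this is the higher of the two numbers, but the gap to compound 1 lies within the scatter of repeated measurements, so the two cannot be told apart on these data.

Compound 3 `O=C1/C(=C/c2cccc(F)c2)CCc2ccccc21` differs from compound 2 in a single place: fluoro in place of hydrogen on an aromatic carbon. Within the data shown here, no pair of measured compounds shows the effect of this particular change, so there is no measured step to lean on. The change adds one heavy atom and nothing else, and without a precedent the most defensible expectation is a step that stays within the scatter, a 1.2-fold lower number from compound 2 to compound 3 (0.08 log units; within the scatter), estimated rather than known. Compound 3 is therefore expected to give about 100000 nM in this assay, with a plausible range from 40000 nM to 250000 nM.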

Compound 3, half-maximal inhibitory concentration: 61200 nM
Estimate against measurement, compound 3: 1.6-fold (0.21 log units) above; the range from low to high includes it.
By their numbers in this assay, from the lowest: compounds 3, 1 and 2 (each within the scatter of the next).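

Putting fluoro in place of hydrogen on an aromatic carbon, meta to a large group, gives a 2.0-fold lower number from compound 2 to compound 3 (0.30 log units; within the scatter) in this assay. Among these compounds, this is the first measured step for this change at this position, and it shows that a single fluorine here does not move the number clearly beyond what repeated measurements of the same compound could produce, so compound 2 and compound 3 cannot be told apart on these data. Nothing shown here offers a measured explanation for the size of this step.

As far as these compounds go, it remains open whether a different group at this same place, such as a chlorine atom, a trifluoromethyl group or an amine, would give a step that lies clearly beyond the scatter, and in which direction that step would go. From the compounds shown here alone, it is also open whether fluoro at another position on the same aromatic ring would give a similar step, and whether a repeat measurement of compound 2 and compound 3 would hold the gap between them at its present size.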